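The source may hold more compounds than are shown below. What is called first, only, known or untested is meant among the compounds shown, and "the series" means these compounds.

Among the compounds with values here, compound 3, with the structure `COc1cc(NC(=O)Nc2cc(Nc3ccc(Br)cc3OC)ncn2)cc(OC)c1`, is the compound to beat among the three measured so far. In a functional assay on NCI-H520 cells (Homo sapiens) for inhibition, read by MTT assay, with a stated time of 48 h, tested at 10 uM (a lower number here means less inhibition, a higher number more inhibition at the concentration tested (going by the name of the read-out)), compound 3 gives 36.1%, the highest of the three numbers. Compound 1, `COc1cc(NC(=O)Nc2cc(Nc3ccc(F)c(Cl)c3)ncn2)cc(OC)c1`, gives 25.5% in this assay, and compound 2, `CCc1cccc(Nc2cc(NC(=O)Nc3cc(OC)cc(OC)c3)ncn2)c1`, gives 23%. The two measured steps that lead to compound 3 both change the aryl group on the nitrogen of the shared core: a number 10.6 percentage points higher from compound 1 to compound 3 (beyond the scatter) and a number 13.1 percentage points higher from compound 2 to compound 3 (beyond the scatter). Between compound 1 and compound 2 the change is a number 2.5 percentage points lower from compound 1 to compound 2 (within the scatter).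

Compound 4, `COc1cc(NC(=O)Nc2cc(Nc3ccc(OC)c(C)c3)ncn2)cc(OC)c1`, differs from compound 3 at the same place: 4-methoxy-3-methylphenyl in place of 4-bromo-2-methoxyphenyl on a nitrogen on an aromatic ring. Since the two steps that bear on this position, from compound 1 and from compound 2 to compound 3, were both modest gains, and the 4-bromo-2-methoxyphenyl that gave them now leaves, a modest loss is expected in this assay, with the read-out for compound 4 estimated as a number 10.1 percentage points lower from compound 3 to compound 4 (beyond the scatter). Compound 4 is therefore expected to give about 26%, within a range from 14% to 38%.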

Compound 4, a percentage reported as inhibition, at one concentration (the size of the read-out at that concentration, not a potency): 13.5%
Beside the measured number, compound 4's estimate is 12.5 percentage points above it; the measured number lies below the stated range.
By their numbers in this assay, from the lowest: compounds 4, 2 and 1 (each within the scatter of the next, the first and the last beyond it); then compound 3.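

In this assay the change to 4-methoxy-3-methylphenyl gives a number 22.6 percentage points lower from compound 3 to compound 4 (beyond the scatter) as the largest step yet seen at this position, although the groups that leave and enter have the same count of heavy atoms and one oxygen each. The same group gives a number 12 percentage points lower from compound 1 to compound 4 (beyond the scatter) and a number 9.5 percentage points lower from compound 2 to compound 4 (within the scatter) in the other two comparisons, so compound 3 stands clear of the other three, and a methoxy on the ring does not by itself keep the number of compound 3. Nothing available accounts for these differences.

The compounds shown leave open whether the higher number of compound 3 follows the bromine, the placing of its methoxy, or both together, since the two groups differ in more than one substituent. They also leave open how this position would respond to an amine or a carboxylic acid on the aryl ring.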